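This account rests on a few compounds, and the source may have more. Where it says the series, first, only, none or still open, it means among the compounds named here.

In an assay on cell membranes for binding affinity to Fatty-acid amide hydrolase 1 (Rattus norvegicus) (on this read-out lower numbers stand for stronger inhibition and higher numbers for weaker inhibition), three compounds built on a shared core have been measured so far. Compound 1 `Cc1ccc(-c2cccc(OC(=O)NC3CCCCC3)c2)cc1` gives 155 nM. Compound 2 `Cc1cccc(-c2cccc(OC(=O)NC3CCCCC3)c2)c1` gives 61.8 nM, and compound 3 `O=C(NC1CCCCC1)Oc1cccc(-c2cccc(Cc3ccccc3)c2)c1` gives 1860 nM. On these numbers compound 3 stands highest of the three, with compound 1 nearest below it and compound 2 furthest below it.

Two steps connect the measured compounds. Moving the methyl, a 2.5-fold lower number from compound 1 to compound 2 (0.40 log units; beyond the scatter), was a modest step. Adding a phenyl to the methyl, a 30-fold higher number from compound 2 to compound 3 (1.48 log units; beyond the scatter), was a large step toward weaker inhibition.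

Compound 4 `O=C(NC1CCCCC1)Oc1cccc(-c2cccc(CO)c2)c1` differs from compound 3 by hydroxy in place of phenyl on a saturated chain carbon bound to an aromatic carbon. Among the measured compounds shown here, this change takes out the phenyl whose entry produced the large rise in the step from compound 2 to compound 3, but puts a hydroxy in its place, and no measured step shows what a hydroxy on this chain carbon does. The expectation is therefore a large step toward lower numbers, probably stopping short of compound 2. Compound 4 is expected to give about 150 nM, within a range from 40 nM to 600 nM. The expected step, a 12-fold lower number from compound 3 to compound 4 (1.09 log units; beyond the scatter), is estimated from a 30-fold higher number from compound 2 to compound 3 (1.48 log units; beyond the scatter), the step in which the phenyl now removed first entered.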

Compound 4, half-maximal inhibitory concentration: 8.67 nM
Estimate against measurement, compound 4: 17-fold (1.24 log units) above, and the stated range ends above it.
By their numbers in this assay, from the lowest: compound 4; then compound 2; then compound 1; then compound 3.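

In this assay, among the compounds shown here, the earlier compounds showed only a rise on the saturated chain carbon bound to an aromatic carbon, but hydroxy in place of phenyl at this place gives a 210-fold lower number from compound 3 to compound 4 (2.33 log units; beyond the scatter), so the same position can also move the number strongly downward. The result is more than the removal of the phenyl: hydroxy in place of hydrogen gives a 7.1-fold lower number from compound 2 to compound 4 (0.85 log units; beyond the scatter), which carries the number beyond that of the methyl compound rather than merely back to it, and 3-(hydroxymethyl)phenyl in place of 4-methylphenyl gives an 18-fold lower number from compound 1 to compound 4 (1.25 log units; beyond the scatter), leaving compound 4 with the lowest number of the four. Nothing at hand accounts for these changes.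

The compounds shown leave open whether the drop belongs to the hydroxy itself, since a methoxymethyl, an aminomethyl or a carboxylic acid at this place would separate the hydroxy from other groups on the same carbon. They also leave open whether a longer chain, such as a hydroxyethyl, would keep the low number of compound 4 or lose it.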